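Swapping a bromo for trifluoromethoxy on a quinone-like core

This account rests on a few compounds, and the source may have more. Where it says the series, first, only, none or still open, it means among the compounds named here.

Measured so far:
- compound 1, `Cc1nc2c([nH]1)C(=O)C(Nc1ccc(OC(F)(F)F)cc1)=C(Cl)C2=O`: 3000 nM
- compound 2, `O=C1C=C(Nc2ccc(Br)cc2)C(=O)c2[nH]c(-c3ccccn3)nc21`: 12000 nM

Of the compounds shown here, two have been tested in an ADME assay (Rattus norvegicus) for inhibition; a higher number here means a weaker inhibitor, a lower number a stronger inhibitor. Compound 1 gives 3000 nM, while compound 2 gives 12000 nM. Of the two numbers, compound 2 has the higher one, so it is the weaker inhibitor; its gap to compound 1 lies beyond the usual scatter of this assay. The two differ in several places at once, so no single change can be credited with that gap.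

Compound 3, `O=C1C=C(Nc2ccc(OC(F)(F)F)cc2)C(=O)c2[nH]c(-c3ccccn3)nc21`, keeps the core of compound 2 and changes one thing: trifluoromethoxy in place of bromo on an aromatic carbon. Among the measured compounds shown here, no pair of measured compounds isolates this exact change. For the measured compounds named here, the only hint is that compound 1, which also carries the trifluoromethoxy aniline, gives 3000 nM, but its core differs as well, so the hint is weak.

Compound 3 is expected to move modestly toward stronger inhibition, a step of a 1.7-fold lower number from compound 2 to compound 3 (0.23 log units; within the scatter) in this assay. Compound 3 is estimated at 7000 nM, with a likely range from 2500 nM to 20000 nM.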

Compound 3, half-maximal inhibitory concentration: 20000 nM
Beside the measured number, compound 3's estimate is 2.9-fold (0.46 log units) below it; the range from low to high includes it.
By their numbers in this assay, from the lowest: compound 1; then compounds 2 and 3 (each within the scatter of the next).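

In this assay, among the compounds shown here, trifluoromethoxy in place of bromo on an aromatic carbon, para to a large group, gives a 1.7-fold higher number from compound 2 to compound 3 (0.22 log units; within the scatter) on the shared core, and this is the first pair in which the aniline substituent is the only difference. A single bromine atom gives way to a group of 5 heavy atoms that brings 1 hydrogen-bond acceptor, yet the two numbers cannot be told apart, so this pair offers no sign that the choice between these two groups matters at this position. Nothing measured here offers an explanation for this result.

The compounds shown leave open whether an amine, a carboxylic acid or a longer chain at this place would move the number beyond the scatter, since bromo and trifluoromethoxy are the only two groups compared there. They also leave open whether the same swap would read alike on the core of compound 1, which carries trifluoromethoxy and gives 3000 nM in this assay, because no bromo partner for compound 1 is among them.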